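A few compounds are considered here, and "the series" means these few. Any claim that something is new, unique, unknown or untested is made for them only; others in the source may bear on it.

Notes on the amide series in an ADME assay on microsomes from liver (Homo sapiens) for metabolic stability; a higher number here means faster removal of the compound, a lower number slower removal. Going by the values given here, compound 1 `COc1ccc(-c2cnc(NC(=O)c3ccc(F)cc3)n2C)cc1` gives 30 uL/min and sits second highest of the three numbers known so far. Compound 2 `O=C(Nc1ncc(-c2ccccc2)o1)c1ccc(F)cc1` gives 90 uL/min, a higher number than compound 1 beyond the scatter, while compound 3 `Cn1c(-c2cccc(Cl)c2)cnc1NC(=O)c1ncc[nH]1` gives 8 uL/min, the lowest of the three and below compound 1 beyond the scatter. Compound 4 `COc1ccc(-c2cnc(NC(=O)c3ncc[nH]3)n2C)cc1` is not yet measured; it differs from compound 1 in one place: 1H-imidazol-2-yl in place of 4-fluorophenyl on a carbonyl carbon. Compound 3 also carries 1H-imidazol-2-yl on its carbonyl carbon and gives the lowest number, so a downward step in this assay is expected for compound 4, of about a 2.5-fold lower number from compound 1 to compound 4 (0.40 log units; beyond the scatter), likely beyond the scatter. The estimate for compound 4 is 12 uL/min, within a range of 5 uL/min to 30 uL/min.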

Compound 4, intrinsic clearance in a liver preparation (reported as CLH), per the amount of preparation that the assay uses in the Homo sapiens assay: < 7 uL/min
Compound 4 was reported as a limit (the forecaster's own chance of this, stated with the estimate: 5%); middle value at least 1.7-fold (0.23 log units) from the limit.
By their numbers in the Homo sapiens assay, from the lowest: compound 3; then compound 1; then compound 2. At a limit, below all of these: compound 4.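

Going by these compounds alone, in the Homo sapiens assay, 1H-imidazol-2-yl in place of 4-fluorophenyl on a carbonyl carbon gives an at least 4.2-fold lower number from compound 1 to compound 4 (0.63 log units; beyond the scatter), the first reading of this change on a single core, and its size is only a bound: the limit of < 7 uL/min in the Homo sapiens assay, at which 1 of the 4 values shown sits. In a physicochemical assay for solubility, read by nephelometry, measured as kinetic solubility, at pH 6.5 (on this read-out lower numbers stand for lower solubility and higher numbers for higher solubility), compound 1 gives < 1.6 ug/mL as a limit. In the physicochemical assay compound 4 gives 6.3 ug/mL as a measured number, so the same change also reads as an at least 3.9-fold higher number from compound 1 to compound 4 (0.59 log units; beyond the scatter) in that assay.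

Going by these compounds, whether other groups on this carbonyl carbon, such as a primary amine on a short chain or a carboxylic acid, would shift both read-outs remains open. Within the data shown here, no pair shows this change on another core.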